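Halogen swap on the aryl ring of the shared core

The source may hold more compounds than are shown below. What is called first, only, known or untested is meant among the compounds shown, and "the series" means these compounds.

Compound 1 `O=C(COc1ccc(Cl)cc1)Nc1nc(-c2ccc(Cl)cc2)cs1` and compound 2 `O=C(COc1ccc(Br)cc1)Nc1nc(-c2ccc(Cl)cc2)cs1` differ only by chloro in place of bromo on an aromatic carbon. In a functional assay on Ehrlich cells (Mus musculus) for cytotoxicity, read by MTT assay, with a stated time of 48 h (a lower number here means a stronger inhibitor, a higher number a weaker inhibitor), compound 2 gives 52100 nM, and compound 1 gives 51900 nM; the step is a 1.0-fold lower number from compound 2 to compound 1 (0.00 log units; within the scatter). Compound 3 `Cc1ccc(OCC(=O)Nc2nc(-c3ccc(Br)cc3)cs2)cc1` gives 55800 nM in this assay; the difference between the cores of compound 2 and compound 3 is not broken down here. Compound 4 `Cc1ccc(OCC(=O)Nc2nc(-c3ccc(Cl)cc3)cs2)cc1` is not yet measured. It differs from compound 3 by chloro in place of bromo on an aromatic carbon, the same change as from compound 2 to compound 1, at a place described in the same words. Since that earlier step was within the scatter, the expected step from compound 3 to compound 4 in this assay is a 1.0-fold lower number from compound 3 to compound 4 (0.01 log units; within the scatter). The estimate for compound 4 in this assay is 55000 nM, between 35000 nM and 90000 nM.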

Compound 4, half-maximal inhibitory concentration: 40600 nM
Compound 4: middle estimate off by 1.4-fold (0.13 log units), on the high side; the range from low to high includes it.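

Chloro in place of bromo on an aromatic carbon has now been read on two cores in this assay, and the two steps do not differ: the same change on two cores in this assay, a 1.0-fold lower number (0.00 log units; within the scatter) from compound 2 to compound 1 and a 1.4-fold lower number (0.14 log units; within the scatter) from compound 3 to compound 4, 1.4-fold (0.14 log units) apart, within the scatter of two such steps. The new step is a 1.4-fold lower number from compound 3 to compound 4 (0.14 log units; within the scatter), while putting methyl where bromo stood gives a 1.3-fold lower number from compound 2 to compound 4 (0.11 log units; within the scatter) and methyl in place of chloro on an aromatic carbon gives a 1.3-fold lower number from compound 1 to compound 4 (0.11 log units; within the scatter). This supports carrying the halogen swap between these two cores only as a step too small to read; it does not show that a step beyond the scatter would carry over, or that the agreement extends to other cores.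

As far as these compounds go, whether an amine, a carboxylic acid or a longer chain at the same place would move the number beyond the scatter remains open.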